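This account rests on a few compounds, and the source may have more. Where it says the series, first, only, none or still open, it means among the compounds named here.

Working notes on the series. For the measured compounds named here, in a functional assay on A549 cells (Homo sapiens) for inhibition, read by CCK-8 assay, with a stated time of 48 h (on this read-out higher numbers stand for weaker inhibition and lower numbers for stronger inhibition), compound 3 `COc1ccc(-c2cc3nccc(-c4cc(OC)c(OC)c(OC)c4)n3n2)cc1F` gives 545 nM, the only number in the set. Compound 1 `COc1ccc(-c2cc3nccc(-c4cc(OC)c(OC)c(OC)c4)n3n2)cc1[N+](=O)[O-]` gives > 10000 nM in this assay, a limit. Compound 2 `COc1cc(-c2cc3nccc(-c4c[nH]c5ccccc45)n3n2)cc(OC)c1OC` likewise gives > 10000 nM in this assay, also a limit. Going by the values given here, the one measured step, an at least 18-fold lower number from compound 1 to compound 3 (1.26 log units; beyond the scatter), is large, though it rests on the limit of > 10000 nM in this assay, at which 2 of the 3 values shown sit, and so its size is only a lower bound.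

Compound 4 `COc1cc(-c2ccnc3cc(-c4ccc5c(ccn5C)c4)nn23)cc(OC)c1OC` is to be measured. It differs from compound 3 as follows: 1-methyl-1H-indol-5-yl in place of 3-fluoro-4-methoxyphenyl on an aromatic carbon. Among the compounds with values here, no measured step bears directly on this exchange; the one step available, an at least 18-fold lower number from compound 1 to compound 3 (1.26 log units; beyond the scatter), concerns a different position and says nothing about an indolyl group. Within the data shown here, compound 2 sits at the limit and is the only other indole-bearing member, which argues against confidence. The exchange from compound 3 to compound 4 is therefore expected to give a moderately higher number, a 2.8-fold higher number from compound 3 to compound 4 (0.44 log units; beyond the scatter), with wide uncertainty. Compound 4 is estimated at 1500 nM, within 300 nM to 8000 nM.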

Compound 4, half-maximal inhibitory concentration: 15 nM
Compound 4: the middle estimate sits 100-fold (2.00 log units) above what was measured, and the stated range ends above it.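

This place, on an aromatic carbon of a five-membered aromatic ring with 2 nitrogen, responds strongly to the whole group attached there and not only to a substituent on its phenyl ring: in this assay, 1-methyl-1H-indol-5-yl in place of 3-fluoro-4-methoxyphenyl gives a 36-fold lower number from compound 3 to compound 4 (1.56 log units; beyond the scatter). Unlike the earlier step from nitro to fluoro, this one joins two measured numbers, so its size is a value and not a lower bound. It also shows that a group with one five-membered and one six-membered aromatic ring is compatible with a low number at this place.

As far as these compounds go, what the methyl on the indole nitrogen contributes, and how an amine or a carboxylic acid would read at this place, stays open. Few values here can be compared as numbers: the limit of > 10000 nM in this assay, at which 2 of the 4 values shown sit.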